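Butoxy in Place of Butylamino: Expected Toxicity Limit

The source may hold more compounds than are shown below. What is called first, only, known or untested is meant among the compounds shown, and "the series" means these compounds.

Three close relatives share one core. Compound 1 `CCCOc1nc(N)nc2c1ncn2/C=C1/CC1(CO)CO` carries a propoxy group on an aromatic carbon, compound 2 `CCCCNc1nc(N)nc2c1ncn2/C=C1/CC1(CO)CO` carries a butylamino group there, and compound 3 `Nc1nc(NC2CCCC2)c2ncn(/C=C3/CC3(CO)CO)c2n1` carries a cyclopentylamino group. In an ADME assay on MOLT-3 cells (Homo sapiens) for cytotoxicity, with a stated time of 7 days (on this read-out higher numbers stand for lower toxicity in this test and lower numbers for higher toxicity in this test), compound 1 gives > 20000 nM, which is a limit of the assay rather than a number. In this assay compound 2 gives > 20000 nM, again only a limit. Compound 3 in this assay gives > 20000 nM, also a limit. Because all three values sit at the limit of > 20000 nM in this assay, at which 3 of the 3 values shown sit, the steps between them cannot be sized: a step that the two limits leave unreadable from compound 1 to compound 2, a step that the two limits leave unreadable from compound 1 to compound 3 and a step that the two limits leave unreadable from compound 2 to compound 3. So compound 2 stands where every measured compound stands, at the limit.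

Compound 4 `CCCCOc1nc(N)nc2c1ncn2/C=C1/CC1(CO)CO` has not been measured. It differs from compound 2 in one place: butoxy in place of butylamino on an aromatic carbon. The nearest evidence is that compound 1, an alkoxy compound, and compound 2, an alkylamino compound, both give only the limit, so no readable step exists to guide the size of the change.

Compound 4 is therefore expected to give only a limit too, with an estimate of 50000 nM and a range from 20000 nM to 200000 nM. The expected step is a step that the limit leaves unreadable from compound 2 to compound 4, not visible within the assay.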

Compound 4, half-maximal cytotoxic concentration: > 20000 nM
Compound 4 gave a limit, no number; the forecaster's own chance of this, stated with the estimate: 90%; the middle value lies beyond the limit too.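

Among the compounds shown here, no step from compound 1, compound 2 or compound 3 to compound 4 can be read in this assay, and none among the first three can be read either, as all four compounds stop at the same limit: the limit of > 20000 nM in this assay, at which 4 of the 4 values shown sit.

The compounds shown leave open how far butoxy and butylamino differ in cytotoxicity, and whether any group on this aromatic carbon would give a readable number.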